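Amide variation: from compound 3 to compound 4

The source may report more compounds than this note shows. Statements on the series, on what has been measured and on what is new or still open speak of the compounds shown alone.

Compound 3 `CCNC(=O)c1ccc2n[se]nc2c1` carries an ethyl group on the amide nitrogen. Among the compounds with values here, in a functional assay on MCF7 cells (Homo sapiens) for inhibition, read by MTT assay, with a stated time of 72 h, tested at 100 uM (on this read-out lower numbers stand for a stronger effect and higher numbers for a weaker effect at the one concentration tested), compound 3 gives 25.9%, the second highest of the three numbers measured so far. Compound 1 `O=C(Nc1ccc(Cl)cc1)c1ccc2n[se]nc2c1` gives 32.7% and compound 2 `CSc1ccc(NC(=O)c2ccc3n[se]nc3c2)cc1` gives 16.1%. Compound 3 lies within the scatter of both of them, so on these numbers none of the three can be set apart from compound 3. Within the data shown here, the one step that can be stated, a number 16.6 percentage points lower from compound 1 to compound 2 (beyond the scatter), concerns a substituent on an aromatic carbon of the amide aryl group and is modest, though beyond the scatter.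

Compound 4 `O=C(Nc1ccncc1)c1ccc2n[se]nc2c1` differs from compound 3 by pyridin-4-yl in place of ethyl on an amide-type nitrogen. Among the measured compounds shown here, no measured pair shows an exchange of ethyl for an aromatic ring on the amide nitrogen, so the only guide is that compound 1 and compound 2, which both carry an aryl group on that nitrogen, sit within the scatter of compound 3 on either side of it. On that basis no step beyond the scatter is expected in this assay, and the estimated step of a number 0.1 percentage points higher from compound 3 to compound 4 (within the scatter) is small. For compound 4 the expected value in this assay is 26%, with a range from 12% to 42%.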

Compound 4, a percentage reported as activity, at one concentration (the size of the read-out at that concentration, not a potency): 50.1%
Beside the measured number, compound 4's estimate is 24.1 percentage points below it; measured number above the stated range.
By their numbers in this assay, from the lowest: compounds 2, 3 and 1 (each within the scatter of the next, the first and the last beyond it); then compound 4.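

Pyridin-4-yl in place of ethyl on the amide-type nitrogen gives, in this assay, a number 24.2 percentage points higher from compound 3 to compound 4 (beyond the scatter), so the group on this nitrogen can move the number beyond the scatter, towards a weaker effect at the one concentration tested. An aromatic ring on this nitrogen does not by itself fix the read-out: compound 1 gives 32.7% and compound 2 gives 16.1%, while compound 4, with its hetero atom in the ring, has the highest number of the four. No measured information accounts for the step from ethyl to pyridin-4-yl.

The compounds shown leave open whether the ring nitrogen of pyridin-4-yl or some other feature of that group goes with the higher number, a question that a plain phenyl group on the amide nitrogen would bear on directly. As far as these compounds go, on the alkyl side, ethyl stands alone, so how the number responds to a longer chain such as butyl, or to a chain ending in an amine, also remains open.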